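A few compounds are considered here, and "the series" means these few. Any claim that something is new, unique, unknown or untested is made for them only; others in the source may bear on it.

Values in a functional assay on HCT-116 cells (Homo sapiens) for inhibition, read by sulforhodamine B assay, with a stated time of 48 h, tested at 50 uM (on this read-out higher numbers stand for more inhibition of growth at the one concentration tested and lower numbers for less inhibition of growth), are as follows
compound 1 `COc1ccc(/C=C/C(=O)/C=C/c2ccc(OCc3cn(CCCCCOc4cc(=O)oc5ccccc45)nn3)c(OC)c2)cc1OC` gives 45%
compound 2 `COc1cc(/C=C/C(=O)/C=C/c2cccc3ccccc23)ccc1OCc1cn(CCCCCOc2cc(=O)oc3ccccc23)nn1` gives 42%
compound 3 `COc1ccccc1/C=C/C(=O)/C=C/c1ccc(OCc2cn(CCCCCOc3cc(=O)oc4ccccc34)nn2)c(OC)c1` gives 33%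

Compound 3 at 33% stands clearly apart only from compound 1, with a number 12 percentage points lower from compound 1 to compound 3 (beyond the scatter), and not from compound 2, with a number 9 percentage points lower from compound 2 to compound 3 (within the scatter). Compound 4 `COc1cc(/C=C/C(=O)/C=C/c2ccccc2)ccc1OCc1cn(CCCCCOc2cc(=O)oc3ccccc23)nn1` follows with hydrogen in place of methoxy on an aromatic carbon, so 2-methoxyphenyl becomes phenyl. The measured steps, the third being a number 3 percentage points lower from compound 1 to compound 2 (within the scatter), all exchange this same aromatic group, and none removes the methoxy alone, so they offer only indirect guidance and suggest a small move at most. The expected change is a number 3 percentage points higher from compound 3 to compound 4 (within the scatter), slightly upward and not beyond the scatter. Compound 4 is estimated at 36%, with an expected range of 25% to 48%.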

Compound 4, percent growth inhibition at one concentration: 24%
The estimate for compound 4 lay 12 percentage points above the measured number; measured number outside the range, below it.
By their numbers in this assay, from the lowest: compounds 4, 3, 2 and 1 (each within the scatter of the next, the first and the last beyond it).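

Hydrogen in place of methoxy, the first change at this position that touches the methoxy alone, gives a number 9 percentage points lower from compound 3 to compound 4 (within the scatter) and so does not separate the two groups on this ring. The unsubstituted phenyl does separate from the larger aryl groups, with a number 18 percentage points lower from compound 2 to compound 4 (beyond the scatter) and a number 21 percentage points lower from compound 1 to compound 4 (beyond the scatter) as steps, whereas compound 3 separates only from compound 1. No measurement on hand accounts for these steps.

Open, as far as these compounds go, is whether an amine, a hydroxyl or a longer ethoxy chain in place of the methoxy would move the number beyond the scatter. Also open, from the compounds shown here alone, is how each methoxy of the 3,4-dimethoxyphenyl group contributes on its own.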